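The source may hold more compounds than are shown below. What is called first, only, known or untested is meant among the compounds shown, and "the series" means these compounds.

Measured so far:
compound 1 `N#Cc1cccc(OC(=O)N2CCC(C(c3ccccc3)c3ccccc3)CC2)n1` — > 1000 nM
compound 2 `N#Cc1cccc(OC(=O)N2CCC(Cc3ccccc3)CC2)c1` — 44.7 nM

In an assay on isolated protein for inhibition of Fatty-acid amide hydrolase 1 (Rattus norvegicus), read by fluorescence (a higher number here means a weaker inhibitor, a lower number a stronger inhibitor), compound 1 gives only a limit, > 1000 nM, so no number stands for it; it sits at the limit of > 1000 nM in this assay, at which 1 of the 2 values shown sits. Compound 2 gives 44.7 nM in this assay, a measured number rather than a limit. Within the data shown here, compound 2 differs from compound 1 in more than one place, so the two values show only that compound 2 is the one with a number.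

Compound 3 `N#Cc1ccc(F)c(OC(=O)N2CCC(C(c3ccccc3)c3ccccc3)CC2)c1` is not yet measured. It differs from compound 1 in one place: 5-cyano-2-fluorophenyl in place of 6-cyanopyridin-2-yl on an oxygen next to a carbonyl group. With no measured step of this kind in the series, the size of the change can only be guessed. The expectation is a step towards stronger inhibition, an at least 3.3-fold lower number from compound 1 to compound 3 (0.52 log units; beyond the scatter), reasoned from compound 2 with 44.7 nM, which also carries a carbon-only aryl carbamate. Compound 3 is estimated at 300 nM, with a range from 50 nM to 3000 nM.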

Compound 3, half-maximal inhibitory concentration: > 1000 nM
Compound 3: only a limit was reported (the forecaster's own chance of this, stated with the estimate: 25%); middle value at least 3.3-fold (0.52 log units) away from the limit.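

No step can be read from compound 1 to compound 3 in this assay, as each compound gives only a limit of the assay: the limit of > 1000 nM in this assay, at which 2 of the 3 values shown sit.

The compounds shown leave open whether 5-cyano-2-fluorophenyl or 6-cyanopyridin-2-yl on the shared core gives the stronger inhibition, and by how much.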